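Fluoro on the phenylsulfanyl ring of compound 3

A few compounds are considered here, and "the series" means these few. Any claim that something is new, unique, unknown or untested is made for them only; others in the source may bear on it.

Measured so far in an assay on isolated protein for inhibition of RAC-alpha serine/threonine-protein kinase (Homo sapiens), tested at 30 uM; on this read-out higher numbers stand for more inhibition at the one concentration tested (going by the name of the read-out) and lower numbers for less inhibition:
- compound 1 `Fc1ccc(Sc2ncnc3[nH]cnc23)cc1`: 0%
- compound 2 `Cn1cnc2c(Sc3ccc(F)cc3)ncnc21`: 0%
- compound 3 `Fc1ccc(Cn2cnc3c(Sc4ccccc4)ncnc32)cc1`: 13%

Compound 3 stands highest of the three numbers in this assay. Its nearest neighbour on the numbers is compound 1, which gives 0% and so lies a step below it that is beyond the scatter; compound 2, with 0%, lies the same distance below. For the measured compounds named here, the only step between measured compounds that differ in one place is no change at the digits printed from compound 1 to compound 2 (within the scatter), methyl in place of hydrogen on an aromatic nitrogen, and it does not touch the part of the molecule changed here.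

The next compound, compound 4 `Fc1ccc(Cn2cnc3c(Sc4ccc(F)cc4)ncnc32)cc1`, differs from compound 3 by fluoro in place of hydrogen on an aromatic carbon. Going by the values given here, no measured pair shows this change on its own: compound 1 and compound 2 carry the 4-fluorophenyl on sulfur but lack the fluorobenzyl of compound 3, so their values cannot be read as a step for this change. With nothing bearing on it directly, the expectation is a step of a number 3 percentage points lower from compound 3 to compound 4 (within the scatter), that is, none beyond the scatter. Compound 4 is therefore estimated at 10% in this assay, within a range of 0% to 25%.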

Compound 4, a percentage reported as inhibition, at one concentration (the size of the read-out at that concentration, not a potency): 0%
The estimate for compound 4 lay 10 percentage points above the measured number; the range from low to high includes it.
By their numbers in this assay, from the lowest: compounds 1, 2 and 4 (each within the scatter of the next); then compound 3.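

In this assay, for the compounds shown here, the fluoro on the phenylsulfanyl ring gives the first reading for a change at this position, para to a large group: a number 13 percentage points lower from compound 3 to compound 4 (beyond the scatter), a modest step that takes the 4-fluorobenzyl compound down to the level of the two compounds without that group. With the (4-fluorophenyl)sulfanyl group held fixed, the group on the aromatic nitrogen makes no readable difference, with no change at the digits printed from compound 2 to compound 4 (within the scatter) and no change at the digits printed from compound 1 to compound 4 (within the scatter), so the 4-fluorobenzyl shows no gain on this read-out when the fluoro is present. No measurement at hand accounts for the loss on adding the fluoro.

The compounds shown leave open whether the step belongs to fluoro in particular or would also appear with another group at this place, such as chloro, methoxy, an amine or a carboxylic acid. Also open, from the compounds shown here alone, is whether a 4-fluorobenzyl replaced by a longer chain on the aromatic nitrogen would lift the phenylsulfanyl compound further above the floor of this single-concentration read-out, where the whole series sits low.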